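Shortening the Chain: Compound 4 Predicted from Compound 3

This account rests on a few compounds, and the source may have more. Where it says the series, first, only, none or still open, it means among the compounds named here.

In a functional assay on A549 cells (Homo sapiens) for cytotoxicity, read by MTT assay, with a stated time of 72 h (a lower number here means a stronger inhibitor, a higher number a weaker inhibitor), compound 3 `COc1ccc(COCNc2n[n+]([O-])c3ccccc3[n+]2[O-])cc1` gives 3320 nM, the second highest of the three numbers recorded. Its nearest neighbour is compound 1 `CCCCCOCNc1n[n+]([O-])c2ccccc2[n+]1[O-]`, which in this assay gives 2900 nM; the step of a 1.1-fold higher number from compound 1 to compound 3 (0.06 log units; within the scatter) lies within the scatter. Compound 2 `[O-][n+]1nc(NCOCc2ccccc2)[n+]([O-])c2ccccc21` gives 4140 nM in this assay, and the step of a 1.2-fold lower number from compound 2 to compound 3 (0.10 log units; within the scatter) is likewise within the scatter, as is a 1.4-fold higher number from compound 1 to compound 2 (0.15 log units; within the scatter).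

Compound 4 `CCCCOCNc1n[n+]([O-])c2ccccc2[n+]1[O-]` differs from compound 3 as follows: propyl in place of 4-methoxyphenyl on a saturated chain carbon bound to an oxygen on a saturated carbon. The step from compound 1 to compound 3, which exchanged butyl for 4-methoxyphenyl at the same place, is the most relevant comparison, and it brought no change beyond the scatter. For the measured compounds named here, nothing among the measured compounds suggests that the exchange of an aryl group for a short chain at this position moves the number appreciably.

Compound 4 is therefore expected to stay close to compound 3, with an estimated step of a 1.1-fold lower number from compound 3 to compound 4 (0.04 log units; within the scatter) in this assay. The estimate for compound 4 is 3000 nM, with a range from 1500 nM to 6000 nM.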

Compound 4, half-maximal inhibitory concentration: 2320 nM
For compound 4 the middle estimate is 1.3-fold (0.11 log units) above the measured one; measured number inside the range.
By their numbers in this assay, from the lowest: compounds 4, 1, 3 and 2 (each within the scatter of the next).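

With this result, the saturated chain carbon bound to an oxygen on a saturated carbon has carried a short propyl group as well as butyl and the two aryl groups, and this assay still separates none of them. Propyl in place of 4-methoxyphenyl gives (a 1.4-fold lower number from compound 3 to compound 4 (0.16 log units; within the scatter)) and propyl in place of phenyl gives (a 1.8-fold lower number from compound 2 to compound 4 (0.25 log units; within the scatter)), so removing the aromatic ring, in either of these two exchanges, takes the number beyond the scatter in neither. Trimming the chain from butyl to propyl gives (a 1.3-fold lower number from compound 1 to compound 4 (0.10 log units; within the scatter)), which adds the first change of chain length at this place, also within the scatter.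

The compounds shown leave open whether a much longer chain, or an amine or a carboxylic acid at the end of the chain, would move the number beyond the scatter. The reason for these small steps also stays open, and no measurement at hand speaks to it.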